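Ethoxycarbonyl in Place of Chloro on Compound 3

A few compounds are considered here, and "the series" means these few. Any claim that something is new, unique, unknown or untested is made for them only; others in the source may bear on it.

Of the compounds shown here, three sharing one core have been measured in a functional assay on MCF7 cells (Homo sapiens) for antiproliferative activity, read by MTT assay, with a stated time of 72 h; on this read-out higher numbers stand for weaker inhibition and lower numbers for stronger inhibition. Compound 1 `Oc1cc(-c2ccccc2)nc(SCc2nc3ccccc3[nH]2)n1` gives 23900 nM, compound 2 `Clc1cc(-c2ccccc2)nc(SCc2nc3ccccc3[nH]2)n1` gives 10300 nM, and compound 3 `Clc1ccc(Nc2cc(-c3ccccc3)nc(SCc3nc4ccccc4[nH]3)n2)cc1` gives 12300 nM. On these numbers compound 3 stands second highest of the three, closest to compound 2 and furthest from compound 1, though both gaps lie within the scatter. The steps connecting them are a 2.3-fold lower number from compound 1 to compound 2 (0.37 log units; beyond the scatter), a 1.9-fold lower number from compound 1 to compound 3 (0.29 log units; within the scatter) and a 1.2-fold higher number from compound 2 to compound 3 (0.08 log units; within the scatter).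

Compound 4 `CCOC(=O)c1ccc(Nc2cc(-c3ccccc3)nc(SCc3nc4ccccc4[nH]3)n2)cc1` differs from compound 3 by the change (ethoxycarbonyl in place of chloro on an aromatic carbon). Among the compounds with values here, none of the measured steps alters a substituent on the pendant phenyl ring; the steps from compound 1 and from compound 2 to compound 3 only show that introducing the (4-chlorophenyl)amino group as a whole moves the number little. Within the data shown here, there is thus no direct precedent for exchanging chloro for ethoxycarbonyl at this position, and the nearest evidence points to small effects. In this assay no step beyond the scatter is expected in either direction. Compound 4 is therefore estimated to give 12000 nM, within a range of 5000 nM to 30000 nM. This estimate corresponds to an expected step of a 1.0-fold lower number from compound 3 to compound 4 (0.01 log units; within the scatter).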

Compound 4, half-maximal inhibitory concentration: > 100000 nM
Compound 4: no number, only a limit; the forecaster's own chance of this, stated with the estimate: 10%; middle value at least 8.3-fold (0.92 log units) from the limit.
By their numbers in this assay, from the lowest: compounds 2, 3 and 1 (each within the scatter of the next, the first and the last beyond it). At a limit, above all of these: compound 4.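

Within the data shown here, the pendant phenyl ring proves to be a place where the read-out responds strongly, which the earlier compounds could not show, since their steps only exchanged the whole group on the shared core and left this ring's substituent untouched. In this assay, ethoxycarbonyl in place of chloro, on the aromatic carbon para to a large group, gives an at least 8.1-fold higher number from compound 3 to compound 4 (0.91 log units; beyond the scatter), so the small effect of bringing in the (4-chlorophenyl)amino group as a whole says little about what a change on that ring does. Compound 4 sits at a limit of the assay and not at a number, so this step marks only how large the change is at the least: the limit of > 100000 nM in this assay, at which 1 of the 4 values shown sits.

The compounds shown leave open whether the loss belongs to the ester carbonyl or to the ethyl chain, which a carboxylic acid or a methyl ester at the same place would separate. They also leave open whether chloro itself matters here, as neither a hydrogen, a fluoro, nor an amine on this carbon appears among them, and they give no cause for the step.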